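A few compounds are considered here, and "the series" means these few. Any claim that something is new, unique, unknown or untested is made for them only; others in the source may bear on it.

Series notes. Compound 1 `NS(=O)(=O)c1ccc(C(=O)NNC(=O)c2ccccc2)cc1` and compound 2 `NS(=O)(=O)c1ccc(C(=O)NNC(=O)c2ccc(F)cc2)cc1` share one core; compound 3 `NS(=O)(=O)c1ccc(-c2nnc(-c3ccc(F)cc3)o2)cc1` and compound 4 `NS(=O)(=O)c1ccc(-c2nnc(-c3ccccc3)o2)cc1` share another. The difference between the two cores is not broken down here. In an assay on cells for inhibition of Amine oxidase [flavin-containing] A (Homo sapiens), read by fluorescence and spectrophotometry, using microsomes, with a stated time of 20 min (on this read-out higher numbers stand for weaker inhibition and lower numbers for stronger inhibition), compound 1 gives 62800 nM, compound 2 gives 39600 nM, and compound 3 gives 83800 nM.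

One change recurs twice. From compound 2 to compound 1 it is hydrogen in place of fluoro on an aromatic carbon, and it produced a 1.6-fold higher number from compound 2 to compound 1 (0.20 log units; within the scatter). From compound 3 to compound 4 the same change is made, (hydrogen in place of fluoro on an aromatic carbon), with the place described in identical terms. Compound 4 is not yet measured in this assay.

The step from compound 3 to compound 4 is expected to be a 1.5-fold higher number from compound 3 to compound 4 (0.17 log units; within the scatter), resting on the step from compound 2 to compound 1 of a 1.6-fold higher number from compound 2 to compound 1 (0.20 log units; within the scatter). Compound 4 is therefore estimated at 125000 nM, with a range from 60000 nM to 260000 nM.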

Compound 4, half-maximal inhibitory concentration: 63900 nM
Compound 4: middle estimate off by 2.0-fold (0.29 log units), on the high side, and the stated range covers the measured number.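

On the core of compound 3, the change from 4-fluorophenyl to phenyl gives a 1.3-fold lower number from compound 3 to compound 4 (0.12 log units; within the scatter) in this assay. Set beside the same change on the core of compound 1, the two steps show no detectable difference: the same change on two cores in this assay, a 1.6-fold higher number (0.20 log units; within the scatter) from compound 2 to compound 1 and a 1.3-fold lower number (0.12 log units; within the scatter) from compound 3 to compound 4, 2.1-fold (0.32 log units) apart, within the scatter of two such steps. Neither step lies beyond the scatter, so the notes support only the statement that this change does not separate the compounds on either core; they show no shared effect of the change and no direction for it.

Still open, going by these compounds, is whether another group at the same place on the aromatic ring, such as chloro, methoxy or an amine, would give a step beyond the scatter on either core.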